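The source may report more compounds than this note shows. Statements on the series, on what has been measured and on what is new or still open speak of the compounds shown alone.

Working notes on the series. In a functional assay on K562 cells (Homo sapiens) for antiproliferative activity, read by fluorescence, with a stated time of 3 days (a higher number here means a weaker inhibitor, a lower number a stronger inhibitor), compound 2 (`CCCCCSc1nc(OC(=O)c2cc3ccccc3o2)c2cn[nH]c2n1`) gives 19800 nM. Compound 1 (`CCCCCSc1nc(OC(=O)CC(C)(C)C)c2cn[nH]c2n1`) gives 19800 nM and compound 3 (`O=C(Oc1nc(SCCc2ccccc2)nc2[nH]ncc12)c1cc2ccccc2o1`) gives 19800 nM, so compound 2 stands level with both. The next analogue is compound 4 (`CCCCCSc1nc(OC(=O)c2ccco2)c2cn[nH]c2n1`), which carries furan-2-yl in place of 1-benzofuran-2-yl on a carbonyl carbon. For the measured compounds named here, two measured steps bear on this. The change on the same carbonyl carbon, no change at the digits printed from compound 1 to compound 2 (within the scatter), bears on it directly. The change on the saturated chain, no change at the digits printed from compound 2 to compound 3 (within the scatter), bears on it less directly. No step beyond the scatter is therefore expected in this assay. The estimated step is no change at the digits printed from compound 2 to compound 4 (within the scatter). For compound 4 the estimated value is 19800 nM, with an expected range from 10000 nM to 30000 nM.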

Compound 4, half-maximal inhibitory concentration: 19800 nM
Beside the measured number, compound 4's estimate shows no gap at the digits printed; low and high end bracket the measured number.
By their numbers in this assay, from the lowest: compounds 1, 2, 3 and 4 (each within the scatter of the next).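

Furan-2-yl in place of 1-benzofuran-2-yl on the carbonyl carbon gives no change at the digits printed from compound 2 to compound 4 (within the scatter) in this assay, so the six-membered aromatic ring of carbon only can go without a step in the read-out. Furan-2-yl in place of neopentyl gives no change at the digits printed from compound 1 to compound 4 (within the scatter), so the smaller aromatic group also stands level with the saturated one on this carbon.

With all the compounds shown level, no group at this place has yet been separated from another. On these data alone, whether an amine or a carboxylic acid on the carbonyl carbon would move the value stays open. Nothing available explains why these groups stand level.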